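Hydroxy to nitro on the shared core

The source may hold more compounds than are shown below. What is called first, only, known or untested is meant among the compounds shown, and "the series" means these compounds.

Three compounds share one core and differ in a single substituent on an aromatic carbon. In a functional assay on K562 cells (Homo sapiens) for cytotoxicity (a lower number here means a stronger inhibitor, a higher number a weaker inhibitor), the chloro compound 1 `CCC(CO)Nc1nc(NCc2ccccc2)c2nc(Cl)n(C(C)C)c2n1` gives 91000 nM, the bromo compound 2 `CCC(CO)Nc1nc(NCc2ccccc2)c2nc(Br)n(C(C)C)c2n1` gives 27000 nM, and the hydroxy compound 3 `CCC(CO)Nc1nc(NCc2ccccc2)c2nc(O)n(C(C)C)c2n1` gives 74000 nM. Compound 3 thus sits level with compound 1 within the scatter, and above compound 2. Compound 4 `CCC(CO)Nc1nc(NCc2ccccc2)c2nc([N+](=O)[O-])n(C(C)C)c2n1` brings nitro in place of hydroxy on an aromatic carbon. Steps at this place span a 1.2-fold lower number from compound 1 to compound 3 (0.09 log units; within the scatter), within the scatter, then a 3.4-fold lower number from compound 1 to compound 2 (0.53 log units; beyond the scatter) and a 2.7-fold higher number from compound 2 to compound 3 (0.44 log units; beyond the scatter), both modest. For the measured compounds named here, no nitro precedent exists. The expected change is therefore none beyond the scatter, with an estimated 1.3-fold lower number from compound 3 to compound 4 (0.13 log units; within the scatter). The estimate for compound 4 is 55000 nM, within an expected range of 20000 nM to 130000 nM.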

Compound 4, half-maximal inhibitory concentration: 117000 nM
Compound 4: middle estimate off by 2.1-fold (0.33 log units), on the low side, within the range that was stated.
By their numbers in this assay, from the lowest: compound 2; then compounds 3, 1 and 4 (each within the scatter of the next).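

Nitro, which carries no hydrogen-bond donor, stays level in this assay with hydroxy, which carries one (a 1.6-fold higher number from compound 3 to compound 4 (0.20 log units; within the scatter)), and with chloro (a 1.3-fold higher number from compound 1 to compound 4 (0.11 log units; within the scatter)). Bromo is now the only group of the four set apart at this place (a 4.3-fold higher number from compound 2 to compound 4 (0.64 log units; beyond the scatter)), with compound 2 beyond the scatter from all three others. Nothing at hand accounts for this separation.

Going by these compounds, whether an amine, a carboxylic acid or a longer chain at this place would stay level with compounds 1, 3 and 4 or move towards compound 2 remains open.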